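The compounds below may be only part of what the source reports. "The series", "measured", "known", "first", "only" and "open" are said of these compounds alone.

Measured in a functional assay on MCF7 cells (Homo sapiens) for antiproliferative activity, read by sulforhodamine B assay, with a stated time of 72 h; on this read-out higher numbers stand for weaker inhibition and lower numbers for stronger inhibition:
- compound 1 `O=S(=O)(Nc1nccs1)c1ccc(Nc2nncc3ccccc23)cc1`: 55 nM
- compound 2 `O=S(=O)(Nc1ccccn1)c1ccc(Nc2nncc3ccccc23)cc1`: 53 nM

In this assay, going by the values given here, compound 2 stands within the scatter of compound 1, its only measured neighbour, so the two cannot be ranked. The unmeasured compound 3 `Cc1cc(NS(=O)(=O)c2ccc(Nc3nncc4ccccc34)cc2)no1` has 5-methyl-1,2-oxazol-3-yl in place of pyridin-2-yl on a sulfonamide nitrogen. Among the compounds with values here, one measured step bears on this place. That step, a 1.0-fold lower number from compound 1 to compound 2 (0.02 log units; within the scatter), exchanged 1,3-thiazol-2-yl for pyridin-2-yl and stayed within the scatter. Within the data shown here, no measured compound carries the entering group, so this is thin evidence, and the range is kept wide. No change beyond the scatter is expected in this assay, and the expected step is a 1.1-fold higher number from compound 2 to compound 3 (0.05 log units; within the scatter). For compound 3 the estimated value is 60 nM, with an expected range from 22 nM to 160 nM.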

Compound 3, half-maximal inhibitory concentration: 46 nM
The estimate for compound 3 lay 1.3-fold (0.12 log units) above the measured number, and the stated range covers the measured number.
By their numbers in this assay, from the lowest: compounds 3, 2 and 1 (each within the scatter of the next).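

With 5-methyl-1,2-oxazol-3-yl, a five-membered aromatic ring now sits on the sulfonamide nitrogen, and it carries a methyl group, which neither earlier group has. Even so, this assay gives a 1.2-fold lower number from compound 2 to compound 3 (0.06 log units; within the scatter) and a 1.2-fold lower number from compound 1 to compound 3 (0.08 log units; within the scatter), so pyridin-2-yl, 1,3-thiazol-2-yl and 5-methyl-1,2-oxazol-3-yl cannot be ranked at this place, and a third aromatic ring type joins the two that already could not be separated. Nothing measured here explains why these groups read alike.

All three groups are aromatic rings, so the compounds shown leave open what a plain methyl group, a cyclohexyl ring or a phenyl ring bearing a carboxylic acid would do on this nitrogen. They also leave open whether a change elsewhere on the shared core would move the number further than any change at this place has.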